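A Trichlorophenyl Ether Swapped for a Bromophenyl Ether

The source may hold more compounds than are shown below. What is called first, only, known or untested is meant among the compounds shown, and "the series" means these compounds.

Compound 1 `NC1=NC2(CCOCC2)N(OCCCOc2cc(Cl)c(Cl)cc2Cl)C(N)=N1` stands without a number in an assay on isolated protein for inhibition of Dihydrofolate reductase (Homo sapiens), read by spectrophotometry, using NADPH, with stated times of 5 s and 6 min, tested at 50 uM; on this read-out higher numbers stand for a stronger effect at the one concentration tested and lower numbers for a weaker effect: its entry reads "not determined" (no result reported). Its close relative compound 2 `NC1=NC2(CCSCC2)N(OCCCOc2cccc(Cl)c2Cl)C(N)=N1`, which carries a sulfur-containing core and a dichlorophenyl ether, gives 89.8% in this assay. Compound 3 `NC1=NC2(CCSCC2)N(OCCCOc2ccc(Br)cc2)C(N)=N1` likewise has no result, reported as "not determined" (no result reported). The change to compound 4 `NC1=NC2(CCOCC2)N(OCCCOc2cccc(Br)c2)C(N)=N1` is 3-bromophenyl in place of 2,4,5-trichlorophenyl on an oxygen on a saturated carbon. Compound 1 has no number. The size and direction of this step in this assay cannot be placed against the scatter; what can be said is that only compound 2 offers a measured anchor among these ethers. On that basis compound 4 is expected to give 75% in this assay, with a likely range from 40% to 95%.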

Compound 4, a percentage reported as inhibition, at one concentration (the size of the read-out at that concentration, not a potency): 85.8%
Estimate against measurement, compound 4: 10.8 percentage points below, and the stated range covers the measured number.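

Within the data shown here, compound 1 has no number, so no step from it to compound 4 can be read. What replacing 2,4,5-trichlorophenyl with 3-bromophenyl does on its own stays open, and no measurement shown here bears on a reason for the result of compound 4.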